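A few compounds are considered here, and "the series" means these few. Any claim that something is new, unique, unknown or untested is made for them only; others in the source may bear on it.

The shared core, seen in compound 1 `CCOC(=O)C1=C(C)NC(C)=C(C(=O)OCC)C1c1ccc(OCC(=O)NCc2ccccc2)cc1`, carries an aryl ether whose chain ends in an amide. In a functional assay on the whole organism (strain Wistar) for inhibition, with Rattus norvegicus as the target, read by paw edema, with stated times of 30 min and 3 h, at a dose of 20 mg/kg (a lower number here means less inhibition, a higher number more inhibition at the dose given (going by the name of the read-out)), compound 1 gives 31.1%, the lowest of the three numbers; compound 2 `CCOC(=O)C1=C(C)NC(C)=C(C(=O)OCC)C1c1ccc(OCC(=O)Nc2c(C)cccc2C)cc1` gives 53.9% and compound 3 `CCOC(=O)C1=C(C)NC(C)=C(C(=O)OCC)C1c1ccc(OCC(=O)Nc2nc3ccccc3s2)cc1` gives 65.9%. Both measured steps away from compound 1 lie beyond the scatter: a number 22.8 percentage points higher from compound 1 to compound 2 (beyond the scatter) and a number 34.8 percentage points higher from compound 1 to compound 3 (beyond the scatter), the second being the larger. Compound 4 `CCOC(=O)C1=C(C)NC(C)=C(C(=O)OCC)C1c1ccc(OCc2nnc(S)o2)cc1` differs from compound 1 by 5-sulfanyl-1,3,4-oxadiazol-2-yl in place of benzylcarbamoyl on a saturated chain carbon bound to an oxygen on an aromatic ring. Going by the values given here, neither measured step alters the amide itself, so neither bears directly on this change; they show only that compound 1 stands lowest among the three. A modest rise is expected, a number 10.9 percentage points higher from compound 1 to compound 4 (beyond the scatter), with wide uncertainty. Compound 4 is therefore estimated at 42%, between 22% and 62%.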

Compound 4, a percentage reported as inhibition, in the whole organism at one dose (the size of the read-out at that dose, not a potency): 61.1%
Compound 4: middle estimate off by 19.1 percentage points, on the low side; measured number inside the range.
By their numbers in this assay, from the lowest: compound 1; then compounds 2, 4 and 3 (each within the scatter of the next, the first and the last beyond it).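

At the saturated chain carbon bound to an oxygen on an aromatic ring, the amide is not needed for a high number in this assay: replacing benzylcarbamoyl with 5-sulfanyl-1,3,4-oxadiazol-2-yl gives a number 30 percentage points higher from compound 1 to compound 4 (beyond the scatter). This group without an amide cannot be told apart from the two better amides, with a number 7.2 percentage points higher from compound 2 to compound 4 (within the scatter) and a number 4.8 percentage points lower from compound 3 to compound 4 (within the scatter). No measurement at hand accounts for the rise.

Open, on these data alone, is whether the sulfanyl group or the ring carries the gain, which an amine or a methylsulfanyl group in its place on the oxadiazole would test. As far as these compounds go, a longer chain before the ring also remains open.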